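The source may report more compounds than this note shows. Statements on the series, on what has been measured and on what is new or still open speak of the compounds shown alone.

Of the compounds shown here, two have been measured in a functional assay on HCT-116 cells (Homo sapiens) for inhibition, read by MTT assay, with a stated time of 72 h; a lower number here means a stronger inhibitor of growth, a higher number a weaker inhibitor of growth. Compound 1 `CC(c1ccccc1)N1CCN(c2c(Cl)cnc3[nH]c(-c4ccc(N(C)C)cc4)nc23)CC1` gives 900 nM in this assay, and compound 2 `CN(C)c1ccc(-c2nc3c(N4CCN(CC(=O)Nc5cccnc5)CC4)c(Br)cnc3[nH]2)cc1` gives 1650 nM in this assay. Compound 1 holds the lower of the two numbers, but compound 2 sits within the usual scatter of repeated measurements, so the two cannot be ranked against each other. The measured pair also differs in more than one place, so no single structural step can be read from it.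

Compound 3 `CN(C)c1ccc(-c2nc3c(N4CCN(CC(=O)Nc5ccccc5)CC4)c(Cl)cnc3[nH]2)cc1` has not yet been measured. It differs from compound 1 in one place: (phenylcarbamoyl)methyl in place of 1-phenylethyl on an amine nitrogen in a ring. For the measured compounds named here, no measured pair isolates a change of this kind, so its direction is open. In this assay compound 3 is expected to give about 1200 nM, with a likely range from 450 nM to 3200 nM. The expected step of a 1.3-fold higher number from compound 1 to compound 3 (0.12 log units; within the scatter) is estimated to be small, probably not beyond the scatter.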

Compound 3, concentration for 50% growth inhibition: 2550 nM
Estimate against measurement, compound 3: 2.1-fold (0.33 log units) below; the measured number falls inside the stated range.
By their numbers in this assay, from the lowest: compounds 1, 2 and 3 (each within the scatter of the next, the first and the last beyond it).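

Replacing 1-phenylethyl with (phenylcarbamoyl)methyl on the amine nitrogen in the ring gives a 2.8-fold higher number from compound 1 to compound 3 (0.45 log units; beyond the scatter) in this assay, the first change in a single place among these compounds. The step is modest but beyond the scatter, so the group on this nitrogen does affect the growth-inhibition number, and this amide-bearing group gives the weaker result of the two. Both groups carry one six-membered aromatic ring of carbon only, so the difference lies in the atoms that attach that ring to the nitrogen, though no measurement here explains the step.

This single swap changes several features at once, so it cannot show which of them matters. Going by these compounds, a benzyl group or a longer chain such as 2-phenylethyl on the same nitrogen would help separate them, and how either would compare remains open.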